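Adding one methyl to compound 2

The source may hold more compounds than are shown below. What is called first, only, known or untested is meant among the compounds shown, and "the series" means these compounds.

- compound 1 `CC(=O)Oc1ccc(/C=C/S(=O)(=O)CCc2ccc(NC(=O)c3ccc([N+](=O)[O-])cc3)cc2)cc1OC(C)=O` gives 160000 nM 
- compound 2 `O=C(Nc1ccc(CCS(=O)(=O)/C=C/c2ccc(O)c(O)c2)cc1)c1ccccc1` gives 238000 nM 

In an ADME assay on TZM cells (Homo sapiens) for cytotoxicity, read by CCK-8 assay, with a stated time of 2 days (on this read-out higher numbers stand for lower toxicity in this test and lower numbers for higher toxicity in this test), compound 2 gives 238000 nM and sits within the usual scatter of compound 1 (160000 nM) so neither stands apart. Compound 3 `Cc1ccc(C(=O)Nc2ccc(CCS(=O)(=O)/C=C/c3ccc(O)c(O)c3)cc2)cc1` alters compound 2 in one place. The change is methyl in place of hydrogen on an aromatic carbon and amounts to methyl in place of hydrogen on an aromatic carbon, para to a large group. For the measured compounds named here, no measured pair shows this change alone, so the expectation in this assay is no step beyond the scatter. The estimated 1.1-fold lower number from compound 2 to compound 3 (0.05 log units; within the scatter) stays inside that scatter. Compound 3 is expected near 210000 nM with a range from 105000 nM to 420000 nM as the estimate.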

Compound 3, half-maximal cytotoxic concentration: 168000 nM
Compound 3: the middle estimate sits 1.3-fold (0.10 log units) above what was measured, within the range that was stated.
By their numbers in this assay, from the lowest: compounds 1, 3 and 2 (each within the scatter of the next).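

In this assay, methyl in place of hydrogen on an aromatic carbon, para to a large group, gives a 1.4-fold lower number from compound 2 to compound 3 (0.15 log units; within the scatter). For the compounds shown here, this is the first single-place comparison, and at this position the methyl does not separate compound 3 from compound 2. No other measurement here bears on why the two compounds read alike.

One small group at one position cannot show how this read-out responds to other substituents. From the compounds shown here alone, whether an amine, a carboxylic acid or a longer chain in place of the methyl would give a step beyond the scatter remains open.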